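Dropping the Cyclohexyl: What the Smaller Compound May Tolerate

A few compounds are considered here, and "the series" means these few. Any claim that something is new, unique, unknown or untested is made for them only; others in the source may bear on it.

Measured so far:
compound 1 `CCCCc1ccc(NC(=S)Nc2cccc(C(F)(F)F)c2)c(C)c1`: 10000 nM
compound 2 `CC[C@H]1CC[C@H](c2ccc(NC(=S)Nc3cccc(C(F)(F)F)c3)cc2)CC1`: 9000 nM

In an ADME assay on MDBK cells (Bos taurus) for cytotoxicity, read by MTT assay, with a stated time of 96 h (a lower number here means that less compound is tolerated, a higher number that more compound is tolerated), compound 1 gives 10000 nM, and compound 2 gives 9000 nM. Compound 2 holds the lower of the two numbers, yet its gap to compound 1 lies within the scatter, so the two cannot be told apart here. Compound 3 `FC(F)(F)c1cccc(NC(=S)Nc2ccccc2)c1` differs from compound 2 by hydrogen in place of 4-ethylcyclohexyl on an aromatic carbon. Among the compounds with values here, no measured pair shows such a change, so the expected step from compound 2 to compound 3 is a guess: a modest rise, a 2.0-fold higher number from compound 2 to compound 3 (0.30 log units; within the scatter), is expected, though it may not clear the scatter. Compound 3 is expected to give 18000 nM, somewhere between 6000 nM and 60000 nM.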

Compound 3, half-maximal cytotoxic concentration: 49000 nM
The estimate for compound 3 lay 2.7-fold (0.43 log units) below the measured number, and the stated range covers the measured number.
By their numbers in this assay, from the lowest: compounds 2 and 1 (each within the scatter of the next); then compound 3.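

In this assay, replacing the 4-ethylcyclohexyl on the aromatic carbon with hydrogen gives a 5.4-fold higher number from compound 2 to compound 3 (0.74 log units; beyond the scatter), so more compound is tolerated once the group is gone. Within the data shown here, this is the first single change in the set whose effect stands clear of the scatter, and it shows that this position can matter for tolerance. Nothing available explains the step.

From the compounds shown here alone, whether the whole group must go for this gain remains open. A methyl or an amine at this position would show whether a much smaller group behaves like hydrogen or like 4-ethylcyclohexyl.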